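Ring size at the thiocarbonyl: a repeated swap

This account rests on a few compounds, and the source may have more. Where it says the series, first, only, none or still open, it means among the compounds named here.

Compound 1, `O=c1c(SC(=S)N2CCCC2)coc2ccc(Cl)cc12`: 24000 nM
Compound 2, `O=c1c(SC(=S)N2CCCCC2)coc2ccc(Cl)cc12`: 13300 nM
Compound 3, `CCOC(=O)c1cc(=O)c2cc(CSC(=S)N3CCCC3)ccc2o1`: 3400 nM

All three compounds were tested in a functional assay on MDA-MB-435S cells (Homo sapiens) for antiproliferative activity, read by MTT assay, with a stated time of 72 h; a higher number here means a weaker inhibitor, a lower number a stronger inhibitor. Compound 1 and compound 2 share one core, and compound 3 has another; the difference between the two cores is not broken down here. In this assay compound 1 gives 24000 nM, and compound 2 gives 13300 nM. Among the compounds with values here, the only change between them is piperidin-1-yl in place of pyrrolidin-1-yl on a thiocarbonyl carbon, and it made the step of a 1.8-fold lower number from compound 1 to compound 2 (0.26 log units; within the scatter). Compound 3, the third measured compound, gives 3400 nM, a lower number than either of the other two, and both gaps are beyond the scatter.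

Compound 4, `CCOC(=O)c1cc(=O)c2cc(CSC(=S)N3CCCCC3)ccc2o1`, has not yet been tested. It differs from compound 3 by piperidin-1-yl in place of pyrrolidin-1-yl on a thiocarbonyl carbon, which is the same change that was made from compound 1 to compound 2, at the same place. Two cases of this change are all that is available here. Taking the measured step as the guide, compound 4 is expected to move from compound 3 by a 1.7-fold lower number from compound 3 to compound 4 (0.23 log units; within the scatter), a small step that, like the earlier one, would sit inside the scatter. On that basis the number for compound 4 is estimated at 2000 nM, with a likely range from 900 nM to 4500 nM.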

Compound 4, half-maximal inhibitory concentration: 2900 nM
For compound 4 the middle estimate is 1.5-fold (0.16 log units) below the measured one; the measured number falls inside the stated range.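

In this assay, placing piperidin-1-yl where pyrrolidin-1-yl stood on the thiocarbonyl carbon gives a 1.2-fold lower number from compound 3 to compound 4 (0.07 log units; within the scatter), so compound 3 and compound 4 cannot be told apart in this measurement. The same swap was already available on the other core, and the two steps do not differ: the same change on two cores in this assay, a 1.8-fold lower number (0.26 log units; within the scatter) from compound 1 to compound 2 and a 1.2-fold lower number (0.07 log units; within the scatter) from compound 3 to compound 4, 1.5-fold (0.19 log units) apart, within the scatter of two such steps

What carries over from one core to the other is therefore a swap with no measurable effect on either core, not a gain in activity, and two pairs of compounds cannot show that a third core would behave alike.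

The compounds shown leave open whether the thiocarbonyl carbon is as undemanding towards groups that differ more from these two rings, such as a morpholine ring or an open-chain diethylamine. They also leave open what happens to the number when the ethyl ester on the core of compound 3 gives way to a free carboxylic acid or an amide, with the ring on the thiocarbonyl carbon kept the same.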